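The source may hold more compounds than are shown below. What is called first, only, known or untested is meant among the compounds shown, and "the series" means these compounds.

Compounds measured in a functional assay on HT-29 cells (Homo sapiens) for inhibition, read by luminescence and CellTiter-Glo, with a stated time of 24 h; on this read-out lower numbers stand for an effect already at smaller amounts and higher numbers for an effect only at larger amounts of compound:
- Compound 1 `CCn1nc(C(=O)N[C@H]2COc3ccccc3N(C)C2=S)nc1Cc1ccccc1`: 17 nM
- Compound 2 `CCCCn1nc(C(=O)N[C@H]2COc3ccccc3N(C)C2=S)nc1Cc1ccccc1`: 510 nM
- Compound 3 `COCCn1nc(C(=O)N[C@H]2COc3ccccc3N(C)C2=S)nc1Cc1ccccc1`: 566 nM

Compound 3 gives the highest of the three numbers in this assay; compound 2 lies nearest, a 1.1-fold higher number from compound 2 to compound 3 (0.05 log units; within the scatter), while compound 1 lies furthest, a 33-fold higher number from compound 1 to compound 3 (1.52 log units; beyond the scatter). Compound 4 `CN1C(=S)[C@@H](NC(=O)c2nc(Cc3ccccc3)n(C3CCOC3)n2)COc2ccccc21` has not yet been measured. It differs from compound 3 at the aromatic nitrogen of the five-membered aromatic ring with three nitrogens (oxolan-3-yl in place of 2-methoxyethyl on an aromatic nitrogen), the new group being a five-membered non-aromatic ring with one hetero atom in place of an open chain.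

Among the measured compounds shown here, the steps that bear on this change are those on the same nitrogen: a 30-fold higher number from compound 1 to compound 2 (1.48 log units; beyond the scatter) and a 33-fold higher number from compound 1 to compound 3 (1.52 log units; beyond the scatter), both large, and a 1.1-fold higher number from compound 2 to compound 3 (0.05 log units; within the scatter), which is within the scatter. Two groups larger than ethyl gave near-identical numbers, so the oxolan-3-yl group is expected to behave like them; the step of a 1.1-fold lower number from compound 3 to compound 4 (0.05 log units; within the scatter) is estimated to stay within the scatter. Compound 4 is therefore expected to give about 500 nM in this assay, within a range of 150 nM to 1800 nM.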

Compound 4, half-maximal effective concentration: 1580 nM
The estimate for compound 4 lay 3.2-fold (0.50 log units) below the measured number, and the stated range covers the measured number.
By their numbers in this assay, from the lowest: compound 1; then compounds 2 and 3 (each within the scatter of the next); then compound 4.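

In this assay, the substituent on this aromatic nitrogen matters beyond ethyl in more than size alone: butyl and 2-methoxyethyl stood within the scatter of each other, yet oxolan-3-yl separates from both, with a 2.8-fold higher number from compound 3 to compound 4 (0.45 log units; beyond the scatter) and a 3.1-fold higher number from compound 2 to compound 4 (0.49 log units; beyond the scatter). Replacing the open chain with a five-membered non-aromatic ring, with the hydrogen-bond acceptor count unchanged, therefore adds a modest further rise to the large one already seen against ethyl, and a 93-fold higher number from compound 1 to compound 4 (1.97 log units; beyond the scatter) is the widest gap in the set. Nothing available explains this difference.

Going by these compounds, what cyclopentyl or isopropyl would give on this nitrogen remains open, and so does whether the rise follows from the ring or from its oxygen. On these data alone, it is also open whether methyl would give a number lower than that of compound 1.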